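Phenoxy to isopropoxy on a nicotinic agonist scaffold

This account rests on a few compounds, and the source may have more. Where it says the series, first, only, none or still open, it means among the compounds named here.

Compound 1 `CN1C[C@H]2C=C(c3cccnc3)C[C@H](C2)C1`: in a functional assay on synaptosomes from brain (strain Sprague-Dawley) for agonist activity at Nicotinic acetylcholine receptor alpha6/alpha3/beta2/beta3 (Rattus norvegicus) (on this read-out higher numbers stand for an effect only at larger amounts of compound and lower numbers for an effect already at smaller amounts), compound 1 reaches only the assay limit, > 10000 nM.
Compound 2 `C1=C(c2cncc(Oc3ccccc3)c2)CC2CNCC1C2`: in this assay compound 2 gives 718 nM.
Compound 3 `CN1C[C@@H]2C=C(c3cccnc3)C[C@@H](C2)C1`: in this assay compound 3 gives 855 nM.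

Compound 2 holds the lowest of the two numbers recorded, and its nearest neighbour is compound 3, whose value lies within the usual scatter of it, so the two cannot be told apart. For the measured compounds named here, the only step between measured compounds is the mirror-image pair, where the number falls an at least 11-fold lower number from compound 1 to compound 3 (1.06 log units; beyond the scatter); the cause there can be pointed to only through the fact that compounds 1 and 3 differ only in the configuration as drawn together with the limit of > 10000 nM in this assay, at which 1 of the 3 values shown sits.

Compound 4 `CC(C)Oc1cncc(C2=CC3CNCC(C2)C3)c1` differs from compound 2 by isopropyl in place of phenyl on an oxygen on an aromatic ring. Going by the values given here, no measured step touches this change: the stereo inversion says nothing about replacing phenyl by isopropyl on the ether oxygen. With nothing to lean on, the estimate for compound 4 is kept close to compound 2 with a wide band, 1000 nM between 300 nM and 4000 nM, which is expected to mean a step of a 1.4-fold higher number from compound 2 to compound 4 (0.14 log units; within the scatter).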

Compound 4, half-maximal effective concentration: 1090 nM
Compound 4: middle estimate off by 1.1-fold (0.04 log units), on the low side; measured number inside the range.
By their numbers in this assay, from the lowest: compounds 2, 3 and 4 (each within the scatter of the next). At a limit, above all of these: compound 1.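

In this assay, isopropyl in place of phenyl on an oxygen on an aromatic ring gives a 1.5-fold higher number from compound 2 to compound 4 (0.18 log units; within the scatter), so compound 2 and compound 4 cannot be told apart. For this pair, the change from a six-membered aromatic ring of carbon only with 6 heavy atoms to a group with no ring and 3 heavy atoms leaves the number within the scatter. Nothing at hand bears on why the two compounds read alike.

As far as these compounds go, it remains open whether a methoxy group, an amine or a carboxylic acid at this place would also leave the number within the scatter. From the compounds shown here alone, compound 2 and compound 4 are drawn without configuration, so it also remains open how their mirror-image forms would compare.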